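Fluorophenyl chain variants of a sulfamide piperidine quinazoline series

The source may hold more compounds than are shown below. What is called first, only, known or untested is meant among the compounds shown, and "the series" means these compounds.

Measured so far in an assay on cells for inhibition of Ectonucleotide pyrophosphatase/phosphodiesterase family member 1 (Homo sapiens), with a stated time of 60 min, tested at 1 uM; a higher number here means more inhibition at the concentration tested (going by the name of the read-out), a lower number less inhibition:
compound 1 `COc1cc2nc(/C=C/c3ccncc3)nc(N3CCC(CCNS(N)(=O)=O)CC3)c2cc1OC`: 79%
compound 2 `COc1cc2nc(/C=C/c3cccc(F)c3)nc(N3CCC(CCNS(N)(=O)=O)CC3)c2cc1OC`: 14%
compound 3 `COc1ccccc1/C=C/c1nc(N2CCC(CCNS(N)(=O)=O)CC2)c2cc(OC)c(OC)cc2n1`: 74%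

Compound 3 stands second highest of the three numbers. Compound 1 gives 79%, and the step of a number 5 percentage points lower from compound 1 to compound 3 (within the scatter) is within the scatter, so the two cannot be ordered. Compound 2 gives 14%, and the step of a number 60 percentage points higher from compound 2 to compound 3 (beyond the scatter) is large.

Compound 4 `COc1cc2nc(CCc3ccc(F)cc3)nc(N3CCC(CCNS(N)(=O)=O)CC3)c2cc1OC` is not yet measured. It differs from compound 3 in one place: 2-(4-fluorophenyl)ethyl in place of 2-(2-methoxyphenyl)ethenyl on an aromatic carbon.

Among the compounds with values here, no measured step saturates the double bond, so that part of the change has no precedent here. The aryl part does: the step of a number 65 percentage points lower from compound 1 to compound 2 (beyond the scatter) and the step of a number 60 percentage points higher from compound 2 to compound 3 (beyond the scatter) both show that a fluorophenyl without the methoxy sits far lower than the pyridin-4-yl and 2-methoxyphenyl analogues. Compound 4 carries a fluorophenyl on a shortened, saturated chain, so a large step downward in this assay is expected, estimated as a number 49 percentage points lower from compound 3 to compound 4 (beyond the scatter). For compound 4 the estimated value is 25%, with a range of 5% to 55%.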

Compound 4, a percentage reported as inhibition, at one concentration (the size of the read-out at that concentration, not a potency): 69%
Compound 4: middle estimate off by 44 percentage points, on the low side, outside the stated range (above it).
By their numbers in this assay, from the lowest: compound 2; then compounds 4, 3 and 1 (each within the scatter of the next).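

In this assay, the step of a number 5 percentage points lower from compound 3 to compound 4 (within the scatter) and the step of a number 10 percentage points lower from compound 1 to compound 4 (within the scatter) show that the saturated 2-(4-fluorophenyl)ethyl group at this aromatic carbon keeps compound 4 level with both, so a fluorophenyl group does not by itself go with a low number, and a double bond in the chain is not needed for a high one. Within the data shown here, the step of a number 55 percentage points higher from compound 2 to compound 4 (beyond the scatter) leaves compound 2 as the only low compound of the four, though its group differs from that of compound 4 in both the fluorine position and the chain. No measurement given here accounts for this result.

The compounds shown leave open whether the fluorine position or the double bond sets the number of compound 2, as no pair here changes only one of them. Also open, from the compounds shown here alone, is how a 2-(4-fluorophenyl)ethenyl group, or a longer chain carrying an amine, would behave at this aromatic carbon.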